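Ring swap on the fused core: compound 3 to compound 4

The compounds below may be only part of what the source reports. "The series", "measured", "known", "first", "only" and "open" are said of these compounds alone.

Three compounds of this series have been run in a physicochemical assay for solubility, read by HPLC, using the shake flask method, measured as kinetic solubility, with a stated time of 2 h, at pH 7.4; on this read-out lower numbers stand for lower solubility and higher numbers for higher solubility. Compound 1 `Cc1cc(NCc2cccnc2)n2nc(C)c(-c3ccccc3)c2n1` gives 110000 nM. Compound 2 `Cc1cc(NCc2ccco2)n2nc(C)c(-c3ccccc3)c2n1` returns only a limit, < 5000 nM; this is the limit of < 5000 nM in this assay, at which 1 of the 3 values shown sits. For the measured compounds named here, the step of an at least 22-fold lower number from compound 1 to compound 2 (1.34 log units; beyond the scatter) is the only single-point change measured so far, and it sits on the saturated chain carbon bound to the ring nitrogen. Compound 3 `Cc1cc(NCc2ccccn2)n2ncc(-c3cccc(F)c3)c2n1` gives 5000 nM in this assay, the lowest of the two numbers; its nearest neighbour is compound 1, which sits higher, beyond the scatter.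

Compound 4 `Cc1cc(NCc2ccccn2)n2ncc(C3=CCOCC3)c2n1` differs from compound 3 in one place: a group of 6 heavy atoms (5 carbon, 1 oxygen; one six-membered non-aromatic ring with 1 hetero atom) in place of a group of 7 heavy atoms (6 carbon, 1 fluorine; one six-membered aromatic ring of carbon only), on an aromatic carbon. Going by the values given here, none of the measured steps touches this position, so no measured step bears directly on the change; the only step seen, from a pyridin-3-yl to a furan-2-yl on the chain, is of a different kind. With nothing to calibrate against, a small step upward in this assay is expected for compound 4, a 2.4-fold higher number from compound 3 to compound 4 (0.38 log units; beyond the scatter), with the range kept wide. Compound 4 is estimated at 12000 nM, between 4000 nM and 40000 nM.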

Compound 4, solubility: 171000 nM
The estimate for compound 4 lay 14-fold (1.15 log units) below the measured number, outside the stated range (above it).
By their numbers in this assay, from the lowest: compound 3; then compounds 1 and 4 (each within the scatter of the next).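

In this assay the aromatic carbon of the five-membered aromatic ring now has a measured step of its own: the six-membered non-aromatic ring with one oxygen, in place of 3-fluorophenyl, gives a 34-fold higher number from compound 3 to compound 4 (1.53 log units; beyond the scatter) and so counts as a large step, as does the one on the chain. The rest of the structure is the same in this pair, so the whole step belongs to this one position. No measured property at hand accounts for the size of the step.

This single swap removes the fluorine and the aromatic ring and brings in the oxygen and the ring double bond together, so the compounds shown do not separate these changes. Going by these compounds, how a saturated tetrahydropyran-4-yl or a piperidine ring would read at this carbon stays open.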